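Bromo-hydroxyphenyl hydrazone in a cytotoxicity series

The source may hold more compounds than are shown below. What is called first, only, known or untested is meant among the compounds shown, and "the series" means these compounds.

Measured compounds:
Compound 1 `O=C(CSc1nnc(-c2ccncc2)o1)N/N=C/c1ccc(Br)cc1`: in a functional assay on SW 1116 cells (Homo sapiens) for cytotoxicity, read by MTT assay, with a stated time of 48 h (on this read-out higher numbers stand for weaker inhibition and lower numbers for stronger inhibition), compound 1 gives 21300 nM.
Compound 2 `O=C(CSc1nnc(-c2ccncc2)o1)N/N=C/c1ccccc1[N+](=O)[O-]`: in this assay compound 2 gives 30700 nM.

Compound 2 stands highest of the two numbers, yet its step of a 1.4-fold higher number from compound 1 to compound 2 (0.16 log units; within the scatter) keeps it within the scatter of compound 1. Compound 3 `O=C(CSc1nnc(-c2ccncc2)o1)N/N=C/c1cc(Br)ccc1O` differs from compound 2 by 5-bromo-2-hydroxyphenyl in place of 2-nitrophenyl on a carbon with a double bond to nitrogen. Going by the values given here, no measured step covers this change; the only comparison, compound 1 against compound 2, shows no movement beyond the scatter. For compound 3 the step of a 1.2-fold lower number from compound 2 to compound 3 (0.09 log units; within the scatter) in this assay is therefore expected to stay within the scatter. Compound 3 is estimated at 25000 nM, between 8000 nM and 80000 nM.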

Compound 3, half-maximal inhibitory concentration: 8150 nM
The estimate for compound 3 lay 3.1-fold (0.49 log units) above the measured number, within the range that was stated.
By their numbers in this assay, from the lowest: compound 3; then compounds 1 and 2 (each within the scatter of the next).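

On a carbon with a double bond to nitrogen, the earlier change of group moved nothing beyond the scatter, but 5-bromo-2-hydroxyphenyl does: this assay gives a 3.8-fold lower number from compound 2 to compound 3 (0.58 log units; beyond the scatter) and a 2.6-fold lower number from compound 1 to compound 3 (0.42 log units; beyond the scatter). This position therefore does respond to the group it carries, and compound 3 has the lowest number of the three. No measured finding bears on what lies behind this result. The compounds shown leave open whether the step belongs to the hydroxy group or to the bromine. A phenyl carrying only the hydroxy group, or a methoxy group in its place, would separate the two.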